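Benzyloxy on the chain-substituted core: cytotoxicity outlook

The compounds below may be only part of what the source reports. "The series", "measured", "known", "first", "only" and "open" are said of these compounds alone.

Compound 2 `CNCCOCCn1nc(OC)c2cc([N+](=O)[O-])ccc21` holds the lowest number of the two measured in an ADME assay on Vero cells (Chlorocebus sabaeus) for cytotoxicity, read by flow cytometry and propidium iodide staining, with a stated time of 72 h; on this read-out lower numbers stand for stronger inhibition and higher numbers for weaker inhibition: compound 2 gives 87600 nM. Compound 1 `Cn1nc(OCc2ccccc2)c2cc([N+](=O)[O-])ccc21` gives 194000 nM in this assay, a higher number than compound 2 by a margin beyond the scatter. Compound 3 `CNCCOCCn1nc(OCc2ccccc2)c2cc([N+](=O)[O-])ccc21` is not yet measured; it differs from compound 2 by phenyl in place of hydrogen on a saturated chain carbon bound to an oxygen on an aromatic ring. Going by the values given here, compound 1 already carries this benzyloxy group on its core, yet its value offers no direct step to compound 3. A step from compound 2 to compound 3 in this assay of a 1.3-fold lower number from compound 2 to compound 3 (0.10 log units; within the scatter) is expected, small and likely within the scatter. Compound 3 is therefore estimated at 70000 nM, ranging from 30000 nM to 160000 nM.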

Compound 3, half-maximal inhibitory concentration: 214000 nM
Beside the measured number, compound 3's estimate is 3.1-fold (0.49 log units) below it; the whole stated range lies below it.
By their numbers in this assay, from the lowest: compound 2; then compounds 1 and 3 (each within the scatter of the next).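

In this assay, going by these compounds alone, methoxy to benzyloxy gives a 2.4-fold higher number from compound 2 to compound 3 (0.39 log units; beyond the scatter), the first reading of this change at this position. With benzyloxy on the core, (2-(methylamino)ethoxy)methyl in place of hydrogen on a saturated chain carbon bound to an aromatic nitrogen gives a 1.1-fold higher number from compound 1 to compound 3 (0.04 log units; within the scatter), so this read-out does not separate that chain from methyl. Nothing at hand accounts for either step.

Open, from the compounds shown here alone, is whether ethoxy or a longer alkoxy chain in place of benzyloxy reads nearer methoxy or benzyloxy. Also open, going by these compounds, is how a tertiary amine or a carboxylic acid at the chain end reads with benzyloxy on the core.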